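This account rests on a few compounds, and the source may have more. Where it says the series, first, only, none or still open, it means among the compounds named here.

Measured compounds in a functional assay on MCF7 cells (Homo sapiens) for cytotoxicity, read by MTT assay, with a stated time of 72 h; on this read-out higher numbers stand for weaker inhibition and lower numbers for stronger inhibition:
Compound 1 `O=C(NC/C=C\Cn1ccc(=O)[nH]c1=O)c1ccccc1` gives only the assay limit, > 100000 nM.
Compound 2 `O=C(NC/C=C\Cn1cc(F)c(=O)[nH]c1=O)c1ccccc1` likewise gives only the assay limit, > 100000 nM.
Compound 3 `Cc1cn(C/C=C\CNC(=O)c2ccccc2)c(=O)[nH]c1=O` too gives only the assay limit, > 100000 nM.

Compound 1 therefore stands at a limit of this assay and not at a number, and the same holds for the two compounds around it, as the limit of > 100000 nM in this assay, at which 3 of the 3 values shown sit, records. The step from compound 1 to compound 4 `O=C(NC/C=C\Cn1ccc(=O)[nH]c1=O)c1ccc(F)cc1` is fluoro in place of hydrogen on an aromatic carbon. The nearest measured steps are a step that the two limits leave unreadable from compound 1 to compound 2, a step that the two limits leave unreadable from compound 1 to compound 3 and a step that the two limits leave unreadable from compound 2 to compound 3; none of them yields a readable size, since both ends of each sit at the limit. A fluoro in place of hydrogen on an aromatic carbon of the shared core, then, gave no reading above the limit, and there is nothing in these numbers that would let a fluoro on the phenyl ring be read differently. Compound 4 is accordingly expected to sit at or near the same limit in this assay, and the step that the limit leaves unreadable from compound 1 to compound 4 is expected to be nil beyond the scatter. The estimate for compound 4 is 150000 nM, with a range from 50000 nM to 500000 nM.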

Compound 4, half-maximal inhibitory concentration: 2700 nM
Compound 4: the middle estimate sits 56-fold (1.74 log units) above what was measured; measured number outside the range, below it.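

In this assay, going by these compounds alone, the change from phenyl to 4-fluorophenyl, para to a large group, is an at least 37-fold lower number from compound 1 to compound 4 (1.56 log units; beyond the scatter), the first step with a readable size, whereas the steps among compound 1, compound 2 and compound 3 cannot be read. The place of the fluoro therefore counts: the same kind of change on the other ring of compound 1 yields no number in compound 2, while on the six-membered aromatic ring of carbon only it yields one in compound 4. The size remains a bound and not an exact figure, since compound 1 stands at a limit and not at a number: the limit of > 100000 nM in this assay, at which 3 of the 4 values shown sit.

The compounds shown leave open whether this step belongs to fluoro itself or would also follow from a chloro, a methyl or a methoxy at the same place. They also leave open whether 4-fluorophenyl has the same effect on the cores of compound 2 and compound 3.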